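Chloro on the aryl cap: from benzamide to phenylurea

A few compounds are considered here, and "the series" means these few. Any claim that something is new, unique, unknown or untested is made for them only; others in the source may bear on it.

Measured so far in a functional assay on OCI-Ly3 cells (Homo sapiens) for inhibition, read by CellTiter-Glo, with stated times of 48 h and 96 h; on this read-out lower numbers stand for stronger inhibition of growth and higher numbers for weaker inhibition of growth:
compound 1 `CC(C)[C@H](NC(=O)c1ccccc1)C(=O)N1CCC[C@H]1C(=O)N[C@@H](CCCNC(=N)N)C(=O)CF` gives 660 nM;
compound 2 `CC(C)[C@H](NC(=O)c1ccc(Cl)cc1)C(=O)N1CCC[C@H]1C(=O)N[C@@H](CCCNC(=N)N)C(=O)CF` gives 1240 nM;
compound 3 `CC(C)[C@H](NC(=O)Nc1ccccc1)C(=O)N1CCC[C@H]1C(=O)N[C@@H](CCCNC(=N)N)C(=O)CF` gives 1520 nM.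

Compound 4 `CC(C)[C@H](NC(=O)Nc1ccc(Cl)cc1)C(=O)N1CCC[C@H]1C(=O)N[C@@H](CCCNC(=N)N)C(=O)CF` is not yet measured. The two cores differ by anilino in place of phenyl on a carbonyl carbon, a change that gives a 2.3-fold higher number from compound 1 to compound 3 (0.36 log units; beyond the scatter). Compound 2 differs from compound 1 by chloro in place of hydrogen on an aromatic carbon, and in this assay that step is a 1.9-fold higher number from compound 1 to compound 2 (0.27 log units; within the scatter). Compound 4 differs from compound 3 by chloro in place of hydrogen on an aromatic carbon, the same change at the same place. For the measured compounds named here, the only precedent is the step from compound 1 to compound 2, so compound 4 is expected to land a 1.6-fold higher number from compound 3 to compound 4 (0.22 log units; within the scatter), a step that rests on a 1.9-fold higher number from compound 1 to compound 2 (0.27 log units; within the scatter) alone. Compound 4 is therefore estimated at 2500 nM, between 1200 nM and 5000 nM.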

Compound 4, concentration for 50% growth inhibition: 780 nM
The estimate for compound 4 lay 3.2-fold (0.51 log units) above the measured number, and the stated range ends above it.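

Chloro in place of hydrogen did not carry over unchanged from the core of compound 1 to the core of compound 3 in this assay: the same change on two cores in this assay, a 1.9-fold higher number (0.27 log units; within the scatter) from compound 1 to compound 2 and a 1.9-fold lower number (0.29 log units; within the scatter) from compound 3 to compound 4, 3.7-fold (0.56 log units) apart, beyond the scatter of two such steps

Taken singly, the new step, a 1.9-fold lower number from compound 3 to compound 4 (0.29 log units; within the scatter), lies within the scatter, as do a 1.6-fold lower number from compound 2 to compound 4 (0.20 log units; within the scatter) and a 1.2-fold higher number from compound 1 to compound 4 (0.07 log units; within the scatter), so compound 4 cannot be ranked against compound 1, compound 2 or compound 3. This single pair of cores shows that the step need not transfer between cores in this series, but it does not show why, nor how chloro would behave on any other core.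

The compounds shown leave open whether bromo or methyl in place of the chloro would split the two cores in the same way. They also leave open what chloro would do on a carbamate cap.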